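The compounds below may be only part of what the source reports. "The series", "measured", "known", "first", "only" and "open" are said of these compounds alone.

For the measured compounds named here, compound 2, `O=C(c1ccc(OCCCN2CC[C@H](NS(=O)(=O)c3ccc(Br)cc3)C2)cc1)C1CC1`, is the stronger of the two compounds so far measured in an assay on isolated protein for binding affinity to histamine H2 receptor (Homo sapiens); a lower number here means a stronger inhibitor, a higher number a weaker inhibitor: compound 2 gives 290 nM, while compound 1, `O=C(c1ccc(OCCCN2CC[C@H](NS(=O)(=O)c3cccc(Cl)c3)C2)cc1)C1CC1`, gives 700 nM. Going by the values given here, the only step available, a 2.4-fold lower number from compound 1 to compound 2 (0.38 log units; beyond the scatter), arises from putting 4-bromophenyl in place of 3-chlorophenyl on the sulfonyl sulfur. The next compound, compound 3, `Cc1ccccc1S(=O)(=O)N[C@H]1CCN(CCCOc2ccc(C(=O)C3CC3)cc2)C1`, differs from compound 2 at the same position: 2-methylphenyl in place of 4-bromophenyl on a sulfonyl sulfur. Among the compounds with values here, no measured compound carries 2-methylphenyl, so the earlier step offers only indirect guidance; it does show that exchanging the aryl group on the sulfonyl sulfur moves this assay by a modest amount. Since the exchange here is of a different kind from the one measured, a shift of similar size in either direction is plausible, with a weakening considered somewhat more likely. For compound 3 the expected value in this assay is 500 nM, with a range from 150 nM to 1600 nM, which means an expected step of a 1.7-fold higher number from compound 2 to compound 3 (0.24 log units; within the scatter).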

Compound 3, inhibition constant: 2200 nM
Compound 3: middle estimate off by 4.4-fold (0.64 log units), on the low side; the whole stated range lies below it.
By their numbers in this assay, from the lowest: compound 2; then compound 1; then compound 3.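

For the compounds shown here, replacing 4-bromophenyl with 2-methylphenyl on the sulfonyl sulfur moves this assay much further than the earlier exchange did, giving a 7.6-fold higher number from compound 2 to compound 3 (0.88 log units; beyond the scatter), against a 2.4-fold lower number from compound 1 to compound 2 (0.38 log units; beyond the scatter) for the only step known before. The change from 3-chlorophenyl gives a 3.1-fold higher number from compound 1 to compound 3 (0.50 log units; beyond the scatter), so compound 3 is the weakest of the three, and this position now proves more sensitive to the choice of aryl group than the first pair suggested. No evidence is available on what lies behind this loss.

The three compounds change the substituent and its location on the aryl group together, so the contribution of the methyl cannot be separated from that of its place. As far as these compounds go, how an unsubstituted phenyl, or an aryl group carrying an amine or a carboxylic acid, would compare also remains open.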